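Shortening the ether chain in a weak alpha4/beta2 antagonist series

The compounds below may be only part of what the source reports. "The series", "measured", "known", "first", "only" and "open" are said of these compounds alone.

Measured compounds:
Compound 1 `COc1ccc(OCCCCCN2CCCC(COC(=O)c3ccccc3N3C(=O)CC(C)C3=O)C2)cc1OC` — 8320 nM
Compound 2 `O=C(Nc1ccccn1)c1ccccc1-c1ccccc1` — 13600 nM
Compound 3 `c1ccc(CCCN2CCCC(COCc3ccccc3-c3ccccc3)C2)cc1` — 12600 nM

Of the compounds shown here, three have been tested in an in vitro functional assay on HEK ts201 cells for antagonist activity at Neuronal acetylcholine receptor; alpha4/beta2 (Homo sapiens), read by fluorescence and calcium flux; on this read-out higher numbers stand for weaker inhibition and lower numbers for stronger inhibition. Compound 1 `COc1ccc(OCCCCCN2CCCC(COC(=O)c3ccccc3N3C(=O)CC(C)C3=O)C2)cc1OC` gives 8320 nM, the lowest of the three numbers. Its neighbours are compound 3, with 12600 nM, and compound 2, with 13600 nM; both of these lie within the scatter of compound 1, so the three values cannot be told apart.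

The next compound, compound 4 `CC1CC(=O)N(c2ccccc2C(=O)OCC2CCCN(CCCCOc3ccccc3)C2)C1=O`, has not yet been measured. It differs from compound 1 in one place: phenoxy in place of (3,4-dimethoxyphenoxy)methyl on a saturated chain carbon, four bonds along the chain from an amine nitrogen in a ring. Within the data shown here, no step between two measured compounds isolates such a change, so the expectation rests on compound 1 alone and on the general level of the series. Compound 4 is expected to stay close to compound 1 in this assay, with no step beyond the scatter; the change from compound 1 to compound 4 is estimated at a 1.2-fold higher number from compound 1 to compound 4 (0.08 log units; within the scatter). Compound 4 is therefore estimated at 10000 nM, within a range from 3000 nM to 33000 nM.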

Compound 4, half-maximal inhibitory concentration: 1700 nM
Compound 4: the middle estimate sits 5.9-fold (0.77 log units) above what was measured; the measured number lies below the stated range.
By their numbers in this assay, from the lowest: compound 4; then compounds 1, 3 and 2 (each within the scatter of the next).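

At the saturated chain carbon four bonds along the chain from an amine nitrogen in a ring, replacing (3,4-dimethoxyphenoxy)methyl with phenoxy gives a 4.9-fold lower number from compound 1 to compound 4 (0.69 log units; beyond the scatter) in this assay. Among these compounds, this is the first step to lie beyond the scatter, and it shows that neither the methoxy groups nor the longer chain of compound 1 is needed for inhibition at the level of compound 4. Nothing available explains the size of this step.

Because the chain and the methoxy groups change together, the compounds shown do not separate their contributions. On these data alone, it also remains open how a phenoxy carrying a single methoxy group, a phenoxy carrying a fluorine, or a still shorter chain would read at this position.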